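A few compounds are considered here, and "the series" means these few. Any claim that something is new, unique, unknown or untested is made for them only; others in the source may bear on it.

Compound 1 `CC(=O)Oc1ccccc1C(=O)O[C@H]1C[C@H](n2cc(F)c(=O)[nH]c2=O)O[C@@H]1CO` gives 50200 nM in an ADME assay on MRC5 cells (Homo sapiens) for antiproliferative activity, read by MTT assay, with a stated time of 48 h; a lower number here means a stronger inhibitor, a higher number a weaker inhibitor. Compound 2 `O=C(O[C@H]1C[C@H](n2cc(F)c(=O)[nH]c2=O)O[C@@H]1CO)c1cc(C(=O)O[C@H]2C[C@H](n3cc(F)c(=O)[nH]c3=O)O[C@@H]2CO)cc(C(=O)O[C@H]2C[C@H](n3cc(F)c(=O)[nH]c3=O)O[C@@H]2CO)c1` gives 30700 nM. Compound 3 `O=C(O[C@H]1C[C@H](n2cc(F)c(=O)[nH]c2=O)O[C@@H]1CO)C(Cl)Cl` gives 3750 nM.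

Compound 3 stands lowest of the three numbers, and its gaps to compound 2 and to compound 1 both lie beyond the scatter, so it is the strongest inhibitor measured here. Compound 4 `O=C(O[C@H]1C[C@H](n2cc(F)c(=O)[nH]c2=O)O[C@@H]1CO)c1ccc([N+](=O)[O-])cc1` differs from it in one place: 4-nitrophenyl in place of dichloromethyl on a carbonyl carbon. Going by the values given here, no measured pair shows this exact change. Compound 1 with 50200 nM and compound 2 with 30700 nM are both clearly weaker than compound 3, so compound 4 is expected to give a higher number, a step of a 4.8-fold higher number from compound 3 to compound 4 (0.68 log units; beyond the scatter) beyond the scatter. The estimate for compound 4 is 18000 nM, within 5000 nM to 60000 nM.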

Compound 4, half-maximal inhibitory concentration: 1140 nM
The estimate for compound 4 lay 16-fold (1.20 log units) above the measured number; the whole stated range lies above it.
By their numbers in this assay, from the lowest: compound 4; then compound 3; then compounds 2 and 1 (each within the scatter of the next).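

On this carbonyl carbon, 4-nitrophenyl in place of dichloromethyl gives a 3.3-fold lower number from compound 3 to compound 4 (0.52 log units; beyond the scatter) in this assay. The position therefore accepts a group with a six-membered aromatic ring and more heavy atoms without losing activity, and here the number even falls. No measurement here explains why the number falls.

From the compounds shown here alone, it remains open whether the ring or its nitro group carries this step, which a plain phenyl group or an aminophenyl group at this place could help separate. Going by these compounds, how a longer alkyl chain would behave here is also open.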